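Aryl substitution on the chalcone arm and antiproliferative potency

This account rests on a few compounds, and the source may have more. Where it says the series, first, only, none or still open, it means among the compounds named here.

Series notes. Compound 1 `O=C(COc1ccc(C(=O)/C=C/c2ccc(F)c(F)c2)cc1)N[C@H]1CCOC1=O` and compound 2 `O=C(COc1ccc(C(=O)/C=C/c2ccc(F)cc2)cc1)N[C@H]1CCOC1=O` carry fluorinated phenyl groups on the double-bonded chain carbon of the shared core; compound 3 `CC(C)(C)c1ccc(/C=C/C(=O)c2ccc(OCC(=O)N[C@H]3CCOC3=O)cc2)cc1` carries a 4-(tert-butyl)phenyl group there. In a functional assay on MGC-803 cells (Homo sapiens) for antiproliferative activity, read by MTT assay, with a stated time of 72 h (on this read-out lower numbers stand for stronger inhibition and higher numbers for weaker inhibition), compound 1 gives only a limit, > 64000 nM. In this assay compound 2 likewise returns a limit, > 64000 nM. Among the measured compounds shown here, compound 3 is the sole compound with a measured number in this assay, 17200 nM. The two remaining values sit at the limit of > 64000 nM in this assay, at which 2 of the 3 values shown sit. The step that the two limits leave unreadable from compound 1 to compound 2 is therefore unreadable. Both readable steps run the same way: an at least 3.7-fold lower number from compound 1 to compound 3 (0.57 log units; beyond the scatter) and an at least 3.7-fold lower number from compound 2 to compound 3 (0.57 log units; beyond the scatter).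

Compound 4 `O=C(COc1ccc(C(=O)/C=C/c2cccc(Br)c2)cc1)N[C@H]1CCOC1=O` is the member not yet measured: 3-bromophenyl in place of 4-(tert-butyl)phenyl on a double-bonded chain carbon bound to a double-bonded chain carbon. The change runs opposite to the readable steps: a halogenated phenyl again takes the place of the tert-butyl one, the pairing that for compound 1 and compound 2 ended at the limit. Whether the bromine of 3-bromophenyl behaves like fluorine is shown by no pair here; no step involving bromine exists. Expected in this assay: a higher number for compound 4 than for compound 3, the step of a 2.6-fold higher number from compound 3 to compound 4 (0.42 log units; beyond the scatter) likely of at least modest size, with a fair chance that only a limit is returned. The estimate for compound 4 is 45000 nM, range 15000 nM to 130000 nM.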

Compound 4, half-maximal inhibitory concentration: 11900 nM
Beside the measured number, compound 4's estimate is 3.8-fold (0.58 log units) above it; measured number below the stated range.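

In this assay, the step of a 1.4-fold lower number from compound 3 to compound 4 (0.16 log units; within the scatter) gives no separation between 3-bromophenyl and 4-(tert-butyl)phenyl at this place, on a double-bonded chain carbon bound to a double-bonded chain carbon, so among the compounds shown a halogen on this phenyl does not in itself go with the limit. Set against the fluorinated members, the 3-bromophenyl compound reads as the 4-(tert-butyl)phenyl one did, with an at least 5.3-fold lower number from compound 2 to compound 4 (0.73 log units; beyond the scatter) and an at least 5.3-fold lower number from compound 1 to compound 4 (0.73 log units; beyond the scatter). The series now divides into compound 3 and compound 4, which carry measured numbers, and compound 1 and compound 2, whose values are limits and whose step to each other cannot be read: the limit of > 64000 nM in this assay, at which 2 of the 4 values shown sit.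

Still open, on these data alone, is whether the bromine itself or its location on the phenyl accounts for the difference from the fluorinated members, a question that a 4-bromophenyl or an unsubstituted phenyl group at this place would address. Also open, as far as these compounds go, is whether a phenyl bearing a dimethylamino group or a carboxylic acid would stay with compound 3 and compound 4 or fall to the limit.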